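A few compounds are considered here, and "the series" means these few. Any claim that something is new, unique, unknown or untested is made for them only; others in the source may bear on it.

Among the measured compounds shown here, compound 2 `O=C(O)Cc1sc(C(c2ccc(F)cc2)c2ccc(F)cc2)nc1-c1ccoc1` gives 14 nM in an in vitro assay on HEK385-7 cells for displacement of a labelled ligand from prostaglandin D2 receptor 2 (Homo sapiens) (on this read-out higher numbers stand for weaker inhibition and lower numbers for stronger inhibition), the higher of the two numbers measured so far. For the measured compounds named here, its only neighbour is compound 1 `O=C(O)Cc1sc(C(c2ccc(F)cc2)c2ccc(F)cc2)nc1-c1cccc(F)c1`, which in this assay gives 1.4 nM; the step of a 10-fold higher number from compound 1 to compound 2 (1.00 log units; beyond the scatter) leaves compound 2 as the weaker of the pair.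

Compound 3 `O=C(O)Cc1sc(C(c2ccc(F)cc2)c2ccc(F)cc2)nc1-c1ccnc(Cl)c1` differs from compound 2 on the same aromatic carbon: 2-chloropyridin-4-yl in place of furan-3-yl on an aromatic carbon. Going by the values given here, the one measured step that bears on this change is a 10-fold higher number from compound 1 to compound 2 (1.00 log units; beyond the scatter), in which a six-membered aromatic ring bearing a halogen gave way to the furan-3-yl. The change to compound 3 brings back a six-membered aromatic ring bearing a halogen, so a move back towards the number of compound 1 is the working expectation, though the entering ring is not the one that left and the match is only partial.

For compound 3 the expected step is a 4.0-fold lower number from compound 2 to compound 3 (0.60 log units; beyond the scatter), a lower number in this assay. Compound 3 is estimated at 3.5 nM, with a range from 1.2 nM to 12 nM.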

Compound 3, half-maximal inhibitory concentration: 3.1 nM
The estimate for compound 3 lay 1.1-fold (0.05 log units) above the measured number; measured number inside the range.
By their numbers in this assay, from the lowest: compound 1; then compound 3; then compound 2.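

In this assay, 2-chloropyridin-4-yl on this aromatic carbon gives a 4.5-fold lower number from compound 2 to compound 3 (0.65 log units; beyond the scatter), so the low numbers here are not tied to the 3-fluorophenyl alone: a six-membered aromatic ring with one hetero atom and a chlorine also serves. The return is only partial, with a 2.2-fold higher number from compound 1 to compound 3 (0.35 log units; beyond the scatter), though that gap is smaller than a 10-fold higher number from compound 1 to compound 2 (1.00 log units; beyond the scatter), and among these three compounds the furan-3-yl stands highest. No measurement at hand explains these differences.

Ring size, the ring nitrogen and the chlorine all change together from compound 2 to compound 3, so the compounds shown cannot separate their contributions. Open, from the compounds shown here alone, is how an unsubstituted pyridin-4-yl would read, and whether a methoxy group or an amine in place of the chlorine would hold the number.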